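Removing the 4-methylpiperazin-1-yl group from compound 2

This account rests on a few compounds, and the source may have more. Where it says the series, first, only, none or still open, it means among the compounds named here.

compound 1 (`N=C(Nc1ccccc1)c1cc2cn[nH]c2cn1`) gives "not determined" (no result reported)
compound 2 (`COc1ccc(Cn2ncc3cc(C(=N)Nc4ccc(N5CCN(C)CC5)cc4)ncc32)cc1`) gives 5300 nM

These entries come from one cell test (a functional assay on HT-1080 cells (Homo sapiens) for cytotoxicity, read by MTT assay, with a stated time of 72 h; a higher number here means a weaker inhibitor, a lower number a stronger inhibitor). Among the compounds with values here, compound 1 has no reported result, so compound 2, at (5300 nM), holds the only number available, with nothing to rank it against.

Compound 3 (`COc1ccc(Cn2ncc3cc(C(=N)Nc4ccccc4)ncc32)cc1`) differs from compound 2 in a single place, with hydrogen in place of 4-methylpiperazin-1-yl on an aromatic carbon. Within the data shown here, no measured pair shows what such a change does, so any expectation is loose. A modest loss of strength seems most likely, which would appear as a somewhat higher number, but a result within the scatter would be no surprise. The expected step, an estimate only, is (a 1.7-fold higher number from compound 2 to compound 3 (0.23 log units; within the scatter)). Compound 3 is estimated at (9000 nM), with an expected range from (2500 nM) to (30000 nM).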

Compound 3, half-maximal inhibitory concentration: 25700 nM
Estimate against measurement, compound 3: 2.9-fold (0.46 log units) below; measured number inside the range.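

In this assay replacing the 4-methylpiperazin-1-yl group with hydrogen gives a 4.8-fold higher number from compound 2 to compound 3 (0.69 log units; beyond the scatter) in the measured values. This change lies beyond the usual scatter of repeated measurements. Within the data shown here, this is the first measured sign that the group matters: with it on the aromatic carbon, compound 2 is the stronger of the pair. Nothing available explains why the number rises.

Going by these compounds, the pair cannot show whether the whole 4-methylpiperazin-1-yl group is needed, so it remains open whether a piperazin-1-yl group lacking the methyl, a morpholin-4-yl group or a simple dimethylamino group would keep the lower number. On these data alone, with no number for compound 1, which carries hydrogen on the ring nitrogen where compound 3 carries the 4-methoxybenzyl group, the part played by that benzyl group also stays open.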